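This account rests on a few compounds, and the source may have more. Where it says the series, first, only, none or still open, it means among the compounds named here.

Measured compounds:
Compound 1 `CCCNC(=O)c1oc2nc(-c3cccs3)cc(C(F)(F)F)c2c1N`: 64000 nM
Compound 2 `Nc1c(C(=O)N/N=C/c2ccc(Cl)cc2)oc2nc(-c3cccs3)cc(C(F)(F)F)c12`: 83000 nM

Compound 2 was examined in an ADME assay on HEK293 cells (Homo sapiens) for antiproliferative activity, read by MTT assay (a higher number here means a weaker inhibitor, a lower number a stronger inhibitor), where it gives 83000 nM. Compound 1, in this assay, gives 64000 nM; the step of a 1.3-fold higher number from compound 1 to compound 2 (0.11 log units; within the scatter) means the two numbers lie within the scatter of each other, so neither can be called the weaker or the stronger of the pair.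

Compound 3 `CNC(=O)c1oc2nc(-c3cccs3)cc(C(F)(F)F)c2c1N` is the next member. Compared with compound 2 it carries one carbon atom in place of a group of 9 heavy atoms (7 carbon, 1 nitrogen, 1 chlorine; one six-membered aromatic ring of carbon only), on an amide-type nitrogen. Going by the values given here, the one step measured on this amide-type nitrogen, a 1.3-fold higher number from compound 1 to compound 2 (0.11 log units; within the scatter), showed that exchanging a group of 3 heavy atoms for a group of 9 heavy atoms left the number essentially unchanged. The change to compound 3 is the reverse direction with an even smaller group, and no other data bear on it, so no step beyond the scatter is expected in this assay. Compound 3 is therefore estimated at 70000 nM, with a range from 35000 nM to 140000 nM, which corresponds to an expected step of a 1.2-fold lower number from compound 2 to compound 3 (0.07 log units; within the scatter).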

Compound 3, half-maximal inhibitory concentration: 75000 nM
Estimate against measurement, compound 3: 1.1-fold (0.03 log units) below; the range from low to high includes it.
By their numbers in this assay, from the lowest: compounds 1, 3 and 2 (each within the scatter of the next).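

On the amide-type nitrogen, methyl in place of the group of 9 heavy atoms gives a 1.1-fold lower number from compound 2 to compound 3 (0.04 log units; within the scatter) in this assay and so extends the earlier comparison to a group of a single carbon. Hydrogen in place of ethyl on the saturated chain carbon bound to that nitrogen gives a 1.2-fold higher number from compound 1 to compound 3 (0.07 log units; within the scatter) and shows that shortening the chain of compound 1 likewise leaves the numbers within the scatter. All three compounds therefore lie within the scatter of one another across this range of group sizes, and no data at hand account for this.

The compounds shown leave open whether any group on this nitrogen can produce a step beyond the scatter. Going by these compounds, an amine or a carboxylic acid at the end of a longer chain, for example, remains untested among them.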